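The compounds below may be only part of what the source reports. "The series", "measured", "known", "first", "only" and "open" are said of these compounds alone.

Compounds measured so far in this series:
compound 1, `CCCS(=O)(=O)Nc1ccc(F)c(C(=O)c2n[nH]c3ncc(-c4cccc(Cl)c4)cc23)c1F`: 40%
compound 2, `CCCS(=O)(=O)Nc1ccc(F)c(C(=O)c2n[nH]c3ncc(-c4cccc(OC)c4)cc23)c1F`: 6.3%
compound 3, `CCCS(=O)(=O)Nc1ccc(F)c(C(=O)c2n[nH]c3ncc(-c4ccc(O)cc4)cc23)c1F`: 0.75%

All three share one core and differ only in the aromatic group attached to it. In an assay for binding affinity to dual specificity mitogen-activated protein kinase kinase 4 (Homo sapiens), read by KINOMEscan, tested at 100 nM (a higher number here means a weaker effect of the compound at the concentration tested, a lower number a stronger effect), compound 3 gives the lowest of the three numbers. Compound 2 stands nearest, within the scatter (a number 5.6 percentage points lower from compound 2 to compound 3 (within the scatter)); compound 1 stands furthest, beyond the scatter (a number 39.3 percentage points lower from compound 1 to compound 3 (beyond the scatter)).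

Compound 4, `CCCS(=O)(=O)Nc1ccc(F)c(C(=O)c2n[nH]c3ncc(-c4ccc(Cl)cc4Cl)cc23)c1F`, is not yet measured. It differs from compound 3 in one place: 2,4-dichlorophenyl in place of 4-hydroxyphenyl on an aromatic carbon.

Within the data shown here, two measured steps bear on this change: a number 33.7 percentage points lower from compound 1 to compound 2 (beyond the scatter) and a number 39.3 percentage points lower from compound 1 to compound 3 (beyond the scatter). Both are large, and both run from a chloro-bearing aryl to an oxygen-bearing one while lowering the number. Compound 4 returns to a chloro-bearing aryl with no hydrogen-bond donor or acceptor, so the reverse is expected: a large step upward in this assay, toward a weaker effect. Among the measured compounds shown here, no measured compound carries two chloro groups on that aryl; that part of the change is untested. Compound 4 is expected to give 35%, with a range from 10% to 70%. That expectation corresponds to an estimated step of a number 34.3 percentage points higher from compound 3 to compound 4 (beyond the scatter).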

Compound 4, a percentage reported as activity, at one concentration (the size of the read-out at that concentration, not a potency): 22%
Estimate against measurement, compound 4: 13 percentage points above, and the stated range covers the measured number.
By their numbers in this assay, from the lowest: compounds 3 and 2 (each within the scatter of the next); then compound 4; then compound 1.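

In this assay, chloro groups on this aryl do not by themselves hold the number at the level of compound 1: 2,4-dichlorophenyl in place of 3-chlorophenyl gives a number 18 percentage points lower from compound 1 to compound 4 (beyond the scatter) at this position. Among these compounds, compound 4 still stands apart from both oxygen-bearing aryls, with a number 21.3 percentage points higher from compound 3 to compound 4 (beyond the scatter) against 4-hydroxyphenyl and a number 15.7 percentage points higher from compound 2 to compound 4 (beyond the scatter) against 3-methoxyphenyl, so across these four compounds the two oxygen-bearing aryls give the lowest numbers and no compound goes against that order. Nothing available explains this order.

Open, going by these compounds, is whether one chloro group of 2,4-dichlorophenyl accounts for the step from compound 1, which a phenyl keeping only one of them would separate. Also open, on these data alone, is how a phenyl bearing an amine or a carboxylic acid would read at this position.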